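A Methyl Added to the Thiophene Amide

The source may report more compounds than this note shows. Statements on the series, on what has been measured and on what is new or still open speak of the compounds shown alone.

For the measured compounds named here, compound 2 `CCNC(=O)[C@H]1O[C@@H](n2cnc3c(NNC(=O)c4cccs4)nc(Cl)nc32)[C@H](O)[C@@H]1O` gives 737 nM in an assay on CHO cells for displacement of a labelled ligand from adenosine receptor A1 (Homo sapiens) (on this read-out higher numbers stand for weaker inhibition and lower numbers for stronger inhibition), the lowest of the two numbers measured so far. Compound 1 `CCNC(=O)[C@H]1O[C@@H](n2cnc3c(NNC(=O)c4ccco4)nc(Cl)nc32)[C@H](O)[C@@H]1O` gives 3500 nM in this assay, and the step of a 4.7-fold lower number from compound 1 to compound 2 (0.68 log units; beyond the scatter) was a modest one, well beyond the scatter. Compound 3 `CCNC(=O)[C@H]1O[C@@H](n2cnc3c(NNC(=O)c4sccc4C)nc(Cl)nc32)[C@H](O)[C@@H]1O` has not yet been measured; it differs from compound 2 by methyl in place of hydrogen on an aromatic carbon, that is, thiophen-2-yl becomes 3-methylthiophen-2-yl on the carbonyl carbon. Going by the values given here, no measured step bears on this kind of change: the only step known here swaps one five-membered ring for another and says nothing about a methyl on the ring. Compound 3 is therefore expected to stay close to compound 2, with a step of a 1.1-fold lower number from compound 2 to compound 3 (0.05 log units; within the scatter) that need not exceed the scatter. The estimate for compound 3 in this assay is 650 nM, within a range from 200 nM to 2500 nM.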

Compound 3, inhibition constant: 1600 nM
For compound 3 the middle estimate is 2.5-fold (0.39 log units) below the measured one; low and high end bracket the measured number.
By their numbers in this assay, from the lowest: compound 2; then compound 3; then compound 1.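

In this assay, a methyl on this aromatic carbon, two ring bonds from the ring sulfur and next to the ring atom that bears a large group, does not leave the number unchanged: the single added carbon gives a step beyond the scatter (a 2.2-fold higher number from compound 2 to compound 3 (0.34 log units; beyond the scatter)). The methylated thiophene still keeps a lower number than the furan, and that step also lies beyond the scatter (a 2.2-fold lower number from compound 1 to compound 3 (0.34 log units; beyond the scatter)). Nothing measured here accounts for the effect of the methyl.

From the compounds shown here alone, whether an ethyl or a methoxy on the same carbon would move the number further in the same direction remains open. So does whether a methyl on another carbon of the thiophene, or on the furan of compound 1, would produce a step of the same direction and size.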